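This account rests on a few compounds, and the source may have more. Where it says the series, first, only, none or still open, it means among the compounds named here.

Compound 1 `CCOC(=O)c1nn(-c2ccccc2)c(-c2ccc(OC)cc2OC)c1-c1ccccc1` gives 20.5% in a functional assay on the whole organism (strain albino) for inhibition, with Rattus norvegicus as the target, read by paw edema, with stated times of 30 min and 2 h, at a dose of 25 mg/kg by the intraperitoneal route (on this read-out lower numbers stand for less inhibition and higher numbers for more inhibition at the one dose given (going by the name of the read-out)), the highest of the three numbers measured. Among the measured compounds shown here, compound 2 `COc1ccc(C2=NN(C(=O)NS(=O)(=O)c3ccc(Cl)cc3)CC2C)c(OC)c1` gives 14.6% in this assay, a value that lies within the scatter of the one for compound 1 and so cannot be separated from it. Compound 3 `COc1ccc(C2=NN(C(=S)NC(=O)c3ccc(Cl)cc3)CC2c2ccccc2)c(OC)c1` gives 0% in this assay, which stands beyond the scatter below compound 1. Compound 4 `CCOC(=O)c1nn(-c2ccc(Cl)cc2)c(-c2ccc(OC)cc2OC)c1-c1ccccc1` has not been measured; it differs from compound 1 in one place: chloro in place of hydrogen on an aromatic carbon. For the measured compounds named here, no measured pair shows the effect of chloro in place of hydrogen on the shared core, so only a small step is expected, a number 1.5 percentage points higher from compound 1 to compound 4 (within the scatter), not beyond the scatter in either direction. Compound 4 is estimated at 22%, with a range from 8% to 36%.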

Compound 4, a percentage reported as inhibition, in the whole organism at one dose (the size of the read-out at that dose, not a potency): 12.7%
Estimate against measurement, compound 4: 9.3 percentage points above, and the stated range covers the measured number.
By their numbers in this assay, from the lowest: compound 3; then compounds 4, 2 and 1 (each within the scatter of the next).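

Phenyl to 4-chlorophenyl gives the first step in the series that can be read at a single place: in this assay it is a number 7.8 percentage points lower from compound 1 to compound 4 (within the scatter). At this position, on an aromatic carbon para to a large group, chloro in place of hydrogen therefore cannot be separated from hydrogen at the one dose given. No measured evidence bears on this step. On these data alone, whether an amine or a carboxylic acid on the same ring carbon would move the number beyond the scatter stays open, as does any change elsewhere on the shared core.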